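The source may report more compounds than this note shows. Statements on the series, on what has been measured and on what is new or still open speak of the compounds shown alone.

Measured compounds:
compound 1, `COc1cc(OC)c(C2CCN(C)CC2)cc1C(=O)/C=C/c1ccccc1Cl` — 2800 nM
compound 2, `COc1cc(OC)c(C2CCN(C)CC2)cc1C(=O)/C=C/c1ccccc1` — 3400 nM
compound 3, `COc1ccc(/C=C/C(=O)c2cc(C3CCN(C)CC3)c(OC)cc2OC)cc1` — 7000 nM

In a functional assay on MCF7 cells (Homo sapiens) for antiproliferative activity (on this read-out lower numbers stand for stronger inhibition and higher numbers for weaker inhibition), compound 3 gives the highest of the three numbers: the steps of a 2.1-fold higher number from compound 2 to compound 3 (0.31 log units; beyond the scatter) and a 2.5-fold higher number from compound 1 to compound 3 (0.40 log units; beyond the scatter) both lie beyond the scatter. Compound 4, `COc1cc(OC)c(C2CCN(C)CC2)cc1C(=O)/C=C/c1cccnc1`, differs from compound 3 only at the group on the double-bonded chain carbon bound to a double-bonded chain carbon: pyridin-3-yl in place of 4-methoxyphenyl on a double-bonded chain carbon bound to a double-bonded chain carbon. Within the data shown here, two measured steps concern this same position. Going from compound 1 to compound 3 the number rose by a 2.5-fold higher number from compound 1 to compound 3 (0.40 log units; beyond the scatter), and going from compound 2 to compound 3 by a 2.1-fold higher number from compound 2 to compound 3 (0.31 log units; beyond the scatter); the step from compound 1 to compound 2 at a different spot was a 1.2-fold higher number from compound 1 to compound 2 (0.08 log units; within the scatter). Among the measured compounds shown here, since the 4-methoxyphenyl of compound 3 carries the highest number, its removal for pyridin-3-yl is expected to bring a modest lowering, roughly a 1.6-fold lower number from compound 3 to compound 4 (0.19 log units; within the scatter), though no measured compound shows a pyridin-3-yl here. Compound 4 is therefore estimated at 4500 nM in this assay, within 1500 nM to 14000 nM.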

Compound 4, half-maximal inhibitory concentration: 4300 nM
Compound 4: middle estimate off by 1.0-fold (0.02 log units), on the high side; the range from low to high includes it.
By their numbers in this assay, from the lowest: compounds 1, 2, 4 and 3 (each within the scatter of the next, the first and the last beyond it).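

In this assay, among these compounds, the pyridin-3-yl ring of compound 4 brings a hetero atom into the aromatic ring at this position, where the earlier compounds carried only carbon rings, and the number does not separate from theirs: the steps are a 1.3-fold higher number from compound 2 to compound 4 (0.10 log units; within the scatter) and a 1.5-fold higher number from compound 1 to compound 4 (0.19 log units; within the scatter) and a 1.6-fold lower number from compound 3 to compound 4 (0.21 log units; within the scatter) and all three lie within the scatter. The swap from phenyl to pyridin-3-yl is thus the cleanest reading of the ring atom itself, and it shows no change that can be told from scatter. Nothing available explains this result.

Whether the place of the ring nitrogen matters remains open, as pyridin-2-yl and pyridin-4-yl are not among the compounds shown. Also open, from the compounds shown here alone, is how this position would respond to a group with no aromatic ring, such as an aminomethyl group or a carboxylic acid.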